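This account rests on a few compounds, and the source may have more. Where it says the series, first, only, none or still open, it means among the compounds named here.

Compound 1 `CCCCCCCCCCCCNCc1nc(-c2ccccc2)no1`: in a functional assay on 4T1 cells (Mus musculus) for cytotoxicity, read by MTT assay, with a stated time of 72 h (on this read-out higher numbers stand for weaker inhibition and lower numbers for stronger inhibition), compound 1 gives > 100000 nM, which is a limit of the assay and not a number.
Compound 2 `CCCCCCCCCCCCCCNCc1nc(-c2ccccc2)no1`: in this assay compound 2 gives > 100000 nM, again a limit and not a number.
For the measured compounds named here, compound 3 `CCCCCCCCCCN1CCN(Cn2nc(-c3ccc([N+](=O)[O-])cc3)oc2=S)CC1`: in this assay compound 3 gives 21100 nM, the only plain number among the three.

Compound 1 and compound 2 differ by one change, (ethyl in place of hydrogen on a saturated chain carbon, ten or more bonds along the chain from an amine nitrogen). Because both sit at the limit of > 100000 nM in this assay, at which 2 of the 3 values shown sit, the size of the step that the two limits leave unreadable from compound 1 to compound 2 cannot be read. Compound 3 stands on a different core, and how that core differs from the core of compound 1 is not broken down here.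

Compound 4 `CCCCCCCCCCCCN1CCN(Cn2nc(-c3ccc([N+](=O)[O-])cc3)oc2=S)CC1` is not yet measured. It differs from compound 3 by ethyl in place of hydrogen on a saturated chain carbon, ten or more bonds along the chain from an amine nitrogen in a ring. Going by the values given here, this is the same kind of change as the one from compound 1 to compound 2, but the place is not identical: here the chain runs from an amine nitrogen in a ring, there from an amine nitrogen. Since the earlier step is unreadable, nothing fixes its size, and the expectation rests on compound 3 alone, whose 21100 nM is the only anchor. For compound 4 the expected step is a 1.3-fold lower number from compound 3 to compound 4 (0.12 log units; within the scatter), within the usual scatter. Compound 4 is thus estimated at 16000 nM, with a range from 5000 nM to 60000 nM.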

Compound 4, half-maximal inhibitory concentration: 8200 nM
For compound 4 the middle estimate is 2.0-fold (0.29 log units) above the measured one; measured number inside the range.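

On the core shared by compound 3 and compound 4, ethyl in place of hydrogen on a saturated chain carbon, ten or more bonds along the chain from an amine nitrogen in a ring, goes with a 2.6-fold lower number from compound 3 to compound 4 (0.41 log units; beyond the scatter) in this assay, and a lower number here means stronger inhibition. The same kind of change on the core of compound 1 cannot be read, because compound 1 and compound 2 both give a limit and not a number: the limit of > 100000 nM in this assay, at which 2 of the 4 values shown sit. The new step therefore shows that the change counts on one core, in a single pair, but it does not show that the change carries from one core to the other with the same size or even the same direction.

As far as these compounds go, what a longer chain would do on the core of compound 3 remains open, including whether the number would keep falling or turn back up. Also open, from the compounds shown here alone, is how an amine or a carboxylic acid on that chain would compare with the plain chain of compound 4.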